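The source may report more compounds than this note shows. Statements on the series, on what has been measured and on what is new or still open speak of the compounds shown alone.

Compound 1 `COc1ccc(-c2cnc(N)nc2-c2ccccc2)cc1` and compound 2 `CC(C)CC(=O)Nc1ncc(-c2cccc(Cl)c2)c(-c2ccccc2)n1` share a common core. In an assay on CHO cells for displacement of a labelled ligand from adenosine receptor A1 (Homo sapiens), read by scintillation counting, with a stated time of 1 h, tested at 1 uM (a lower number here means less inhibition, a higher number more inhibition at the concentration tested (going by the name of the read-out)), compound 1 gives 56%, and compound 2 gives 56%, so compound 2 stands level with compound 1 within the usual scatter. Compound 3 `OCCCNc1ncc(-c2cccc(Cl)c2)c(-c2ccccc2)n1` has not yet been measured. It differs from compound 2 by 3-hydroxypropyl in place of isobutylcarbonyl on a nitrogen on an aromatic ring. Going by the values given here, no pair of measured compounds isolates this change, so nothing yet shows how large a step it brings. A step from compound 2 to compound 3 of a number 11 percentage points lower from compound 2 to compound 3 (beyond the scatter) is expected, a modest loss at most. Compound 3 is estimated at 45%, between 15% and 75%.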

Compound 3, a percentage reported as inhibition, at one concentration (the size of the read-out at that concentration, not a potency): > 80%
Compound 3: no number, only a limit; the forecaster's own chance of this, stated with the estimate: 0%; middle value at least 35 percentage points from the limit.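

Going by these compounds alone, compound 2 and compound 3 are the first pair here to differ in one place only, and they show that this nitrogen on an aromatic ring is sensitive to its substituent: 3-hydroxypropyl in place of isobutylcarbonyl gives a number at least 24 percentage points higher from compound 2 to compound 3 (beyond the scatter) in this assay. Compound 3 reads > 80%, which is a limit of the assay and not a number. The step therefore has a lower bound but no upper one: the limit of > 80% in this assay, at which 1 of the 3 values shown sits.

The compounds shown do not separate the loss of the carbonyl from the arrival of the hydroxyl at the chain end. Nor do they show how a plain propyl chain, a longer chain or a terminal amine would read at this nitrogen.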